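Moving a Trifluoromethyl Around an Inactive Core

The compounds below may be only part of what the source reports. "The series", "measured", "known", "first", "only" and "open" are said of these compounds alone.

Compound 1 `Nc1nc2ccccn2c1-c1ccc(O)cc1` was tested in an assay on isolated protein for inhibition of ubiquitin carboxyl-terminal hydrolase 47 (Homo sapiens); a higher number here means a weaker inhibitor, a lower number a stronger inhibitor. In this assay compound 1 gives > 100000 nM, which is a limit of the assay and not a number. Compound 2 `COc1ccc(-c2c(N)nc3ccccn23)cc1` carries a methyl in place of hydrogen on an oxygen on an aromatic ring, and in this assay compound 2 gives > 100000 nM, again a limit. Compound 3 `Nc1nc2cc(C(F)(F)F)ccn2c1-c1ccc(O)cc1` carries a trifluoromethyl in place of hydrogen on an aromatic carbon, and in this assay compound 3 gives > 100000 nM, also a limit. The steps a step that the two limits leave unreadable from compound 1 to compound 2 and a step that the two limits leave unreadable from compound 1 to compound 3 thus have no readable size because every value sits at the limit of > 100000 nM in this assay, at which 3 of the 3 values shown sit.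

Compound 4 `Nc1nc2c(C(F)(F)F)cccn2c1-c1ccc(O)cc1` differs from compound 1 by trifluoromethyl in place of hydrogen on an aromatic carbon. The step to compound 3 is the closest parallel, since it also puts a trifluoromethyl on the shared core, yet its size cannot be read. No movement beyond the scatter is expected in this assay. Compound 4 is expected to remain at a limit, estimated at 150000 nM with a range from 50000 nM to 500000 nM. The expected step is a step that the limit leaves unreadable from compound 1 to compound 4.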

Compound 4, half-maximal inhibitory concentration: > 100000 nM
Compound 4 ended at the assay's limit; the forecaster's own chance of this, stated with the estimate: 85%; the middle value does not contradict the limit.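

In this assay compound 4 gives > 100000 nM, which is a limit of the assay and not a number. The step from compound 1 to compound 4 therefore cannot be read: the limit of > 100000 nM in this assay, at which 4 of the 4 values shown sit.

The compounds shown leave open whether any change to the shared core can bring a readable value in this assay.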